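Swapping a Methoxypyridine Amide for a Phenethyl Amide

The source may report more compounds than this note shows. Statements on the series, on what has been measured and on what is new or still open speak of the compounds shown alone.

Compound 1 `COc1cncc(C(=O)Nc2cnn(Cc3c(C)noc3C)c2)c1` has the lowest number among the three measured compounds in a functional assay on cells for antagonist activity at taste receptor type 2 member 8 (Homo sapiens), read by FLIPR and calcium flux, with a stated time of 100 s; on this read-out lower numbers stand for stronger inhibition and higher numbers for weaker inhibition; compound 1 gives 800 nM. Compound 3 `COc1ccc(C(=O)Nc2cnn(Cc3c(C)noc3C)c2)cc1OC` gives 1000 nM, a gap within the usual scatter, so these two cannot be ordered. Compound 2 `Cc1noc(C)c1Cn1cc(NC(=O)c2ccc3ocnc3c2)cn1` gives 3000 nM, a higher number beyond the scatter. Compound 4 `Cc1noc(C)c1Cn1cc(NC(=O)CCc2ccccc2)cn1` has not been measured. It differs from compound 1 in one place: phenethyl in place of 5-methoxypyridin-3-yl on a carbonyl carbon. Among the measured compounds shown here, no measured pair shows this kind of change, so the expectation rests on compound 1 alone. A modest move toward weaker inhibition is expected, a step of a 2.5-fold higher number from compound 1 to compound 4 (0.40 log units; beyond the scatter), beyond the scatter but not large. Compound 4 is therefore estimated at 2000 nM, with a range from 500 nM to 8000 nM.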

Compound 4, half-maximal inhibitory concentration: 400 nM
Compound 4: the middle estimate sits 5.0-fold (0.70 log units) above what was measured; measured number below the stated range.
By their numbers in this assay, from the lowest: compounds 4, 1 and 3 (each within the scatter of the next, the first and the last beyond it); then compound 2.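

In this assay, phenethyl in place of 5-methoxypyridin-3-yl on a carbonyl carbon gives a 2.0-fold lower number from compound 1 to compound 4 (0.30 log units; within the scatter), so the two compounds cannot be ordered. This place therefore accepts an entering group of carbon only, with no hydrogen-bond acceptors, and with its ring carried on a chain, without a clear loss of inhibition. Nothing measured here explains this result. The compounds shown leave open how a benzyl group or a longer chain ending in the same ring would read out at this place. They also leave open whether an amine on the chain would be accepted.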